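Fluoro in Place of Methyl: Compound 3 to Compound 4

The source may report more compounds than this note shows. Statements on the series, on what has been measured and on what is new or still open speak of the compounds shown alone.

Compound 1 `O=C(CCCCCCc1ccccc1Cl)N1CCCC1`: in an assay on HEK293 cells for inhibition of N-acylethanolamine-hydrolyzing acid amidase (Rattus norvegicus), read by LC-MS, with a stated time of 30 min (on this read-out lower numbers stand for stronger inhibition and higher numbers for weaker inhibition), compound 1 reaches only the limit > 100000 nM.
Compound 2 `Cc1ccccc1-c1ccc(CCC(=O)N2CCCC2)cc1`: in this assay compound 2 reaches only the limit > 100000 nM.
Compound 3 `Cc1cccc(-c2ccc(CCC(=O)N3CCCC3)cc2)c1`: in this assay compound 3 gives 16500 nM.

Compound 3 thus holds the only number shown, while the other two sit at the limit of > 100000 nM in this assay, at which 2 of the 3 values shown sit. Going by the values given here, the one measured step, an at least 6.0-fold lower number from compound 2 to compound 3 (0.78 log units; beyond the scatter), moves a methyl from one aromatic carbon to another and carries the value off that limit. Compound 4 `O=C(CCc1ccc(-c2cccc(F)c2)cc1)N1CCCC1` differs from compound 3 by fluoro in place of methyl on an aromatic carbon. Among the compounds with values here, no measured step exchanges methyl for fluoro, so that step gives no direct guide. Compound 4 is therefore expected to show no step beyond the scatter, a 1.2-fold higher number from compound 3 to compound 4 (0.08 log units; within the scatter), with an estimate of 20000 nM and a range from 6000 nM to 70000 nM.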

Compound 4, half-maximal inhibitory concentration: 1800 nM
Compound 4: the middle estimate sits 11-fold (1.05 log units) above what was measured, and the stated range ends above it.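

In this assay, the group on this aromatic carbon, meta to a large group, still matters once the methyl has left the limit: fluoro in place of methyl gives a 9.2-fold lower number from compound 3 to compound 4 (0.96 log units; beyond the scatter). Replacing 2-methylphenyl with 3-fluorophenyl gives an at least 55-fold lower number from compound 2 to compound 4 (1.74 log units; beyond the scatter). The starting point of that step, compound 2, is a limit and not a number: the limit of > 100000 nM in this assay, at which 2 of the 4 values shown sit.

The compounds shown leave open how methoxy, nitrile or an amine would read at this same place. They also leave open whether a second fluoro on this ring would lower the number further.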